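Dichlorophenyl in Place of Methoxyphenyl: Expected Dose

A few compounds are considered here, and "the series" means these few. Any claim that something is new, unique, unknown or untested is made for them only; others in the source may bear on it.

Two compounds have been measured in a functional assay on the whole organism (strain CD-1) with Mus musculus as the target, in the maximal electroshock model, with a stated time of 0.5 h; a higher number here means that more compound is needed for the effect, a lower number that less compound is needed:

Compound 1 `CC1(c2ccccc2)CC(=O)N(CC(=O)N2CCN(c3cccc(Cl)c3)CC2)C1=O`: 300 mg/kg
Compound 2 `COc1ccccc1N1CCN(C(=O)CN2C(=O)CC(C)(c3ccccc3)C2=O)CC1`: 100 mg/kg

Going by the values given here, compound 2 stands at the lowest number of the two; the only neighbour is compound 1, and the step of a 3.0-fold lower number from compound 1 to compound 2 (0.48 log units; beyond the scatter) is beyond the scatter, so compound 2 needs less compound for the effect than compound 1.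

Compound 3 `CC1(c2ccccc2)CC(=O)N(CC(=O)N2CCN(c3cccc(Cl)c3Cl)CC2)C1=O` has not yet been measured. It differs from compound 2 in one place: 2,3-dichlorophenyl in place of 2-methoxyphenyl on an amine nitrogen in a ring.

Among the compounds with values here, only the step from compound 1 to compound 2 bears on this change, and only loosely: there the 3-chlorophenyl gave way to the 2-methoxyphenyl and the number fell by a 3.0-fold lower number from compound 1 to compound 2 (0.48 log units; beyond the scatter). From the compounds shown here alone, compound 3 moves the other way, from the 2-methoxyphenyl back to a chlorine-bearing phenyl, so a rise in the number toward that of compound 1 is the more likely outcome, though a second chlorine is untested here. The expected step is a 2.0-fold higher number from compound 2 to compound 3 (0.30 log units; within the scatter). For compound 3 the estimated value in this assay is 200 mg/kg, with a range from 100 mg/kg to 400 mg/kg.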

Compound 3, minimum effective dose: "not active" (no number reported)
No number was reported for compound 3; no gap can be computed for the estimate.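

In this assay, going by these compounds alone, compound 3 was reported as not active, with no number, so no step from compound 2 or compound 1 to compound 3 can be read. No measured evidence here bears on this result.

The compounds shown leave open whether compound 3 would give a measurable dose under other conditions, and how the 2,3-dichlorophenyl group relates to that outcome.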